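Sulfonamide variation and microsomal stability in one small series

The source may hold more compounds than are shown below. What is called first, only, known or untested is meant among the compounds shown, and "the series" means these compounds.

Measured so far:
compound 1 `O=S(=O)(NCC1COC1)c1cccc(-c2ccc3nccc(-c4ccncc4)c3n2)c1`: 8%
compound 2 `NS(=O)(=O)c1ccc(-c2ccc3nccc(-c4ccncc4)c3n2)cc1`: 36%

In an ADME assay on microsomes from liver (Rattus norvegicus) for metabolic stability, read by LC-MS, using NADPH, with a stated time of 30 min, tested at 0.1 uM (a higher number here means that more of the compound is left, a lower number that less of the compound is left), compound 1 gives 8%, the lowest of the two numbers. Compound 2 gives 36%, a gap beyond the scatter.

Compound 3 `CS(=O)(=O)Nc1cccc(-c2ccc3nccc(-c4ccncc4)c3n2)c1` is not yet measured. methanesulfonamido in place of ((oxetan-3-yl)methyl)sulfamoyl on an aromatic carbon The entering group has no ring and fewer heavy atoms than the group that leaves.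

The step is expected to be a rise beyond the scatter, a number 22 percentage points higher from compound 1 to compound 3 (beyond the scatter), because compound 2 with its smaller sulfamoyl group gives 36%. Only two measured points support this, so the range is wide. Compound 3 is estimated at 30%, within 12% to 55%.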

Compound 3, percent of the compound remaining: 49%
Compound 3: the middle estimate sits 19 percentage points below what was measured; the measured number falls inside the stated range.
By their numbers in this assay, from the lowest: compound 1; then compound 2; then compound 3.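

In this assay, going by these compounds alone, methanesulfonamido in place of ((oxetan-3-yl)methyl)sulfamoyl on an aromatic carbon meta to a large group gives a number 41 percentage points higher from compound 1 to compound 3 (beyond the scatter) as the first comparison that differs in one place. The number left at this position therefore depends strongly on the group it carries, and here the entering group without a ring stands higher. No measurement bears on the reason for this step. The loss of the ring and the change in group size remain inseparable here. Also open, as far as these compounds go, is how an amine, a carboxylic acid or a longer chain on this carbon would compare with compound 3.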